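This account rests on a few compounds, and the source may have more. Where it says the series, first, only, none or still open, it means among the compounds named here.

Compound 1 `COc1cc2c(cc1OC)C(=O)C(C(=O)Nc1ccc(Br)cc1)C2`: 3.03
Compound 2 `CCc1cccc(NC(=O)C2Cc3cc(OC)c(OC)cc3C2=O)c1`: 3.11

In a physicochemical assay for lipophilicity, read by mass spectrometry (on this read-out higher numbers stand for higher lipophilicity and lower numbers for lower lipophilicity), compound 2 gives 3.11 and compound 1 gives 3.03. These two values lie within the scatter of each other, so compound 2 cannot be ranked against compound 1.

Compound 3 `COc1cc2c(cc1OC)C(=O)C(C(=O)Nc1cccc(Br)c1)C2` has not yet been measured. It differs from compound 2 in one place: bromo in place of ethyl on an aromatic carbon. In words, this is bromo in place of ethyl on an aromatic carbon, meta to a large group.

Among the measured compounds shown here, only one measured step bears on this change: a number 0.08 log units higher from compound 1 to compound 2 (within the scatter). That step, 3-ethylphenyl in place of 4-bromophenyl on an amide-type nitrogen, stays within the scatter. For the measured compounds named here, it does not isolate the change at hand, since compound 1 carries 4-bromophenyl where compound 3 carries 3-bromophenyl, and no measured compound shows that swap directly. Going by the values given here, with so small a step as the only guide, no shift beyond the scatter is expected in this assay, in either direction. The expected step is a number 0.06 log units lower from compound 2 to compound 3 (within the scatter). For compound 3 the estimated value is 3.05, with an expected range from 2.75 to 3.35.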

Compound 3, partition coefficient: 3.03
The estimate for compound 3 lay 0.02 log units above the measured number, and the stated range covers the measured number.
By their numbers in this assay, from the lowest: compounds 1, 3 and 2 (each within the scatter of the next).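

In this assay, among the compounds shown here, the step of a number 0.08 log units lower from compound 2 to compound 3 (within the scatter) gives the first direct reading of bromo in place of ethyl on an aromatic carbon, meta to a large group, and on this read-out the two groups cannot be told apart at this place. For the compounds shown here, the step of no change at the digits printed from compound 1 to compound 3 (within the scatter) isolates 3-bromophenyl in place of 4-bromophenyl on the amide-type nitrogen, a swap that no earlier pair showed on its own, and shifting the bromo in this way gives no difference that can be read beyond the scatter. Nothing measured here offers an explanation for why these groups and places read alike.

From the compounds shown here alone, all three compounds carry only bromo or ethyl on that phenyl ring, so it stays open whether an amine, a carboxylic acid or a chain longer than ethyl at the same place would give a step beyond the scatter. Going by these compounds, it also stays open whether any such group would behave alike at the two ring places that the bromo compounds 1 and 3 occupy, since these compounds show that comparison for bromo alone.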